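Swapping a Methyl for 3-Nitrophenyl on Compound 1

The source may report more compounds than this note shows. Statements on the series, on what has been measured and on what is new or still open speak of the compounds shown alone.

Of the compounds shown here, two sharing one core have so far been tested. In a functional assay on HCT-116 cells (Homo sapiens) for inhibition, read by sulforhodamine B assay, with a stated time of 48 h, tested at 50 uM (on this read-out lower numbers stand for less inhibition of growth and higher numbers for more inhibition of growth at the one concentration tested), compound 1 (`COc1ccc([C@@H]2CC(=O)c3cc(CC=C(C)C)c(OC)cc3O2)cc1`) gives 68%, the higher of the two numbers. Compound 2 (`COc1ccc([C@@H]2C/C(=N/O)c3cc(CC=C(C)C)c(OC)cc3O2)cc1`) gives 47%, which lies lower by a margin beyond the usual scatter. Compound 1 therefore stands at the top of this small set.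

Compound 3 (`COc1cc2c(cc1CC=C(C)C)C(=O)C[C@@H](c1ccc(Oc3cccc([N+](=O)[O-])c3)cc1)O2`) has not yet been measured. It departs from compound 1 by one change: 3-nitrophenyl in place of methyl on an oxygen on an aromatic ring, with 3-nitrophenyl in place of methyl on an oxygen on an aromatic ring. Among the measured compounds shown here, no measured compound carries this change, so the data offer no direct guide to its effect, and a wide range is warranted. In this assay, the expected step is small and downward, within the scatter: a number 8 percentage points lower from compound 1 to compound 3 (within the scatter). For compound 3 the expected value is 60%, with an estimated range of 36% to 84%.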

Compound 3, percent growth inhibition at one concentration: 46%
Compound 3: middle estimate off by 14 percentage points, on the high side; measured number inside the range.
By their numbers in this assay, from the lowest: compounds 3 and 2 (each within the scatter of the next); then compound 1.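

Among the compounds shown here, until this result, no measured compound varied the group on this oxygen. In this assay, 3-nitrophenyl in place of methyl on an oxygen on an aromatic ring gives a number 22 percentage points lower from compound 1 to compound 3 (beyond the scatter), so the position is sensitive to this change. Even so, the larger group does not abolish the effect, as compound 3 still gives 46% at the one concentration tested, and no available evidence explains the lower number.

As far as these compounds go, it remains open whether the loss follows the added phenyl ring or its nitro group, a question that a plain phenyl, a 3-aminophenyl or a longer alkyl chain on the same oxygen could help to settle. From the compounds shown here alone, it is also open whether the step would hold at other concentrations or in other cell lines.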